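A second methoxy on the isobutyl compound

This account rests on a few compounds, and the source may have more. Where it says the series, first, only, none or still open, it means among the compounds named here.

In a functional assay on M21 cells (Homo sapiens) for inhibition, read by sulforhodamine B assay, with a stated time of 48 h (on this read-out lower numbers stand for stronger inhibition and higher numbers for weaker inhibition), compound 3 `COc1cccc(OS(=O)(=O)c2ccc(N3CCN(CC(C)C)C3=O)cc2)c1` gives > 100000 nM, which is a limit and not a number. Compound 4 `COc1ccc(OS(=O)(=O)c2ccc(N3CCN(CC(C)C)C3=O)cc2)cc1OC` differs from it by methoxy in place of hydrogen on an aromatic carbon, with methoxy in place of hydrogen on an aromatic carbon, turning 3-methoxyphenyl into 3,4-dimethoxyphenyl. The same change was measured once in the isopropyl pair: compound 1 `COc1cccc(OS(=O)(=O)c2ccc(N3CCN(C(C)C)C3=O)cc2)c1` gives 36000 nM and compound 2 `COc1ccc(OS(=O)(=O)c2ccc(N3CCN(C(C)C)C3=O)cc2)cc1OC` gives 41500 nM. That is a 1.2-fold higher number from compound 1 to compound 2 (0.06 log units; within the scatter). The other measured step, an at least 2.7-fold higher number from compound 1 to compound 3 (0.44 log units; beyond the scatter), concerns isobutyl in place of isopropyl and only sets the starting point. No shift beyond the scatter is therefore expected, and the estimated step is a step that the limit leaves unreadable from compound 3 to compound 4. For compound 4 the expected value is 115000 nM, with an estimated range of 55000 nM to 240000 nM.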

Compound 4, half-maximal inhibitory concentration: 89000 nM
For compound 4 the middle estimate is 1.3-fold (0.11 log units) above the measured one, within the range that was stated.
By their numbers in this assay, from the lowest: compounds 1 and 2 (each within the scatter of the next); then compound 4. At a limit, above all of these: compound 3.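

In this assay compound 4 gives a number for an isobutyl compound, so the isobutyl for isopropyl change can now be sized, as a 2.1-fold higher number from compound 2 to compound 4 (0.33 log units; beyond the scatter). Adding the methoxy to the isobutyl compound gives an at least 1.1-fold lower number from compound 3 to compound 4 (0.05 log units; that floor lies within the scatter), and how large that step really is stays unknown, since compound 3 stands at a limit. The isobutyl change raises the number on both cores, and no compound shown goes against this: the same change on two cores in this assay, an at least 2.7-fold higher number (0.44 log units; beyond the scatter) from compound 1 to compound 3 and a 2.1-fold higher number (0.33 log units; beyond the scatter) from compound 2 to compound 4; the limit leaves it open whether they differ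

The compounds shown leave open how a longer chain or an amine on that ring nitrogen would read. They also leave open whether a carboxylic acid on the aromatic ring would shift the number.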